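Shifting the thiophene attachment point in compound 2

The compounds below may be only part of what the source reports. "The series", "measured", "known", "first", "only" and "open" are said of these compounds alone.

Measured compounds, with their values in a functional assay on A498 cells (Homo sapiens) for antiproliferative activity; a higher number here means a weaker inhibitor of growth, a lower number a stronger inhibitor of growth:
- compound 1 `c1ccc(-c2cc(-c3ccsc3)cc(-c3ccccn3)n2)nc1`; compound 1 gives 0.000097 ug/mL
- compound 2 `c1ccc(-c2cc(-c3ccsc3)cc(-c3cccnc3)n2)nc1`; compound 2 gives 0.64 ug/mL
- compound 3 `c1ccc(-c2cc(-c3ccoc3)cc(-c3ccccn3)n2)nc1`; compound 3 gives 0.000032 ug/mL

Compound 2 stands highest of the three numbers, as a 6600-fold higher number from compound 1 to compound 2 (3.82 log units; beyond the scatter) shows, with compound 3 lying furthest below it. Compound 4 `c1ccc(-c2cc(-c3cccs3)cc(-c3cccnc3)n2)nc1` differs from compound 2 in one place: thiophen-2-yl in place of thiophen-3-yl on an aromatic carbon. Going by the values given here, no measured step moves a thiophene attachment point. Among the compounds with values here, the only step touching that position, a 3.0-fold lower number from compound 1 to compound 3 (0.48 log units; beyond the scatter), was modest, and the pyridine change that set compound 2 apart is untouched here. A step of at most modest size is therefore expected in this assay, in no certain direction. Compound 4 is expected at 0.5 ug/mL, within 0.1 ug/mL to 3 ug/mL. The expected step of a 1.3-fold lower number from compound 2 to compound 4 (0.11 log units; within the scatter) stays near the scatter.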

Compound 4, concentration for 50% growth inhibition: 0.0029 ug/mL
For compound 4 the middle estimate is 170-fold (2.24 log units) above the measured one; the measured number lies below the stated range.
By their numbers in this assay, from the lowest: compound 3; then compound 1; then compound 4; then compound 2.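

In this assay, the attachment point of the thiophene alone proved to matter greatly: with the same atoms joined differently, thiophen-2-yl in place of thiophen-3-yl gave a 220-fold lower number from compound 2 to compound 4 (2.34 log units; beyond the scatter). The earlier change at this position, furan-3-yl in place of thiophen-3-yl, had given only a 3.0-fold lower number from compound 1 to compound 3 (0.48 log units; beyond the scatter), so this position responds to more than a swap of the ring's hetero atom. Nothing measured here accounts for the step. On these data alone, whether thiophen-2-yl acts the same way on the core of compound 1 stays open. So does how an amine or a carboxylic acid would fare at this position.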